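The source may hold more compounds than are shown below. What is called first, only, known or untested is meant among the compounds shown, and "the series" means these compounds.

Values in a functional assay on NCI-H322 cells (Homo sapiens) for cytotoxicity, read by MTT assay, with a stated time of 24 h (a higher number here means a weaker inhibitor, a lower number a stronger inhibitor), for the two measured compounds:

- compound 1, `COc1ccc(/C=C\C(=O)O)c(OCc2cn(-c3ccccc3F)nn2)c1CC=C(C)C`: 45600 nM
- compound 2, `COc1ccc(/C=C\C(=O)O)c(OCc2cn(-c3ccccc3I)nn2)c1CC=C(C)C`: 42300 nM

Both compounds share the same core and differ only in one group on the five-membered ring with three nitrogens. Within the data shown here, the single measured step, a 1.1-fold lower number from compound 1 to compound 2 (0.03 log units; within the scatter), is within the scatter, so the two numbers cannot be told apart. Among the measured compounds shown here, compound 2 gives the smaller of the two numbers, but its only neighbour, compound 1, sits within the scatter of it.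

Compound 3, `COc1ccc(/C=C\C(=O)O)c(OCc2cn(-c3ccc(C#N)cc3)nn2)c1CC=C(C)C`, is not yet measured. It differs from compound 2 as follows: 4-cyanophenyl in place of 2-iodophenyl on an aromatic nitrogen. For the measured compounds named here, the only step that bears on this change is a 1.1-fold lower number from compound 1 to compound 2 (0.03 log units; within the scatter), which exchanged one ring substituent for another at this same place and produced no step beyond the scatter. Nothing measured covers a nitrile, so the range must stay wide. On this evidence the step of a 1.1-fold lower number from compound 2 to compound 3 (0.02 log units; within the scatter) is expected to lie within the scatter. Compound 3 is therefore estimated at 40000 nM, with a range from 14000 nM to 115000 nM in this assay.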

Compound 3, half-maximal inhibitory concentration: 18600 nM
For compound 3 the middle estimate is 2.2-fold (0.33 log units) above the measured one; the measured number falls inside the stated range.
By their numbers in this assay, from the lowest: compound 3; then compounds 2 and 1 (each within the scatter of the next).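

In this assay the group on the aromatic nitrogen of the five-membered ring can shift the result after all, with a 2.3-fold lower number from compound 2 to compound 3 (0.36 log units; beyond the scatter) and with a 2.5-fold lower number from compound 1 to compound 3 (0.39 log units; beyond the scatter) when 4-cyanophenyl enters, whereas the earlier exchange of 2-fluorophenyl for 2-iodophenyl stayed within the scatter. Both new steps are modest, but they point the same way, so 4-cyanophenyl stands apart from the two other groups, which cannot be told from each other here. Nothing available on these compounds gives a reason for this difference, so the result records an effect without explaining it.

This change replaces the halogen with a nitrile and also moves the substituent to a different ring position, so the compounds shown cannot separate the effect of the new group from the effect of its new place, a question that 2-cyanophenyl and 4-iodophenyl would address. As far as these compounds go, it also remains open whether another group at the 4-position of this phenyl ring, such as an amine, would give a similar step or none at all.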